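Fluoro for chloro on compound 2: exposure outlook

The compounds below may be only part of what the source reports. "The series", "measured", "known", "first", "only" and "open" are said of these compounds alone.

In an ADME assay on the whole organism (plasma, strain Sprague-Dawley) for pharmacokinetics, with Rattus norvegicus as the target, with a stated time of 24 h, at a dose of 5 mg/kg by the oral route (on this read-out higher numbers stand for higher exposure at the dose given and lower numbers for lower exposure), compound 1 (`O=S(=O)(Nc1cc(Cl)c(Oc2cncc(Cl)c2)c(Cl)c1)c1ccc(Cl)cc1Cl`) gives 2390 ng.h/mL and compound 2 (`O=S(=O)(Nc1ccc(Oc2cnc3ccccc3c2)c(Cl)c1)c1ccc(Cl)cc1Cl`) gives 50400 ng.h/mL. Compound 2 holds the higher of these two numbers, and its gap to compound 1 lies beyond the usual scatter. Compound 3 (`O=S(=O)(Nc1ccc(Oc2cnc3ccccc3c2)c(F)c1)c1ccc(Cl)cc1Cl`) carries one change from compound 2: fluoro in place of chloro on an aromatic carbon. For the measured compounds named here, no measured pair shows this change, so the expected step is a small fall within the scatter, a 1.7-fold lower number from compound 2 to compound 3 (0.23 log units; within the scatter). For compound 3 the estimated value is 30000 ng.h/mL, with an expected range of 10000 ng.h/mL to 80000 ng.h/mL.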

Compound 3, area under the concentration-time curve: 38000 ng.h/mL
For compound 3 the middle estimate is 1.3-fold (0.10 log units) below the measured one, and the stated range covers the measured number.
By their numbers in this assay, from the lowest: compound 1; then compounds 3 and 2 (each within the scatter of the next).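

In this assay fluoro in place of chloro on an aromatic carbon gives a 1.3-fold lower number from compound 2 to compound 3 (0.12 log units; within the scatter) at this place, ortho to a large group and meta to a large group. For the compounds shown here, this is the first single-place reading: exposure at this position holds with either halogen. No measured evidence bears on this result.

Going by these compounds, whether a methyl or a nitrile at this place would hold exposure remains open. So does whether the same change would read alike on the core of compound 1.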